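This account rests on a few compounds, and the source may have more. Where it says the series, first, only, none or still open, it means among the compounds named here.

Compound 1, `Cc1ccc2[nH]c(-c3cn(-c4ccccc4)nc3-c3ccccc3)nc2c1`: > 50000 nM
Compound 2, `Cc1ccc2[nH]c(-c3cn(-c4ccccc4)nc3-c3ccc(F)cc3)nc2c1`: > 50000 nM
Compound 3, `Clc1ccc(-c2nn(-c3ccccc3)cc2-c2nc3ccccc3[nH]2)cc1`: > 50000 nM

In an ADME assay on HaCaT cells (Homo sapiens) for cytotoxicity, read by MTT assay, with a stated time of 48 h (a higher number here means a weaker inhibitor, a lower number a stronger inhibitor), compound 1 gives > 50000 nM, which is a limit of the assay and not a number. In this assay compound 2 gives > 50000 nM, again a limit. In this assay compound 3 gives > 50000 nM, also a limit. Among the measured compounds shown here, every value so far stands at the limit of > 50000 nM in this assay, at which 3 of the 3 values shown sit.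

Compound 2 differs from compound 1 by fluoro in place of hydrogen on an aromatic carbon. The step that the two limits leave unreadable from compound 1 to compound 2 is therefore unreadable.

Compound 4, `Fc1ccc2[nH]c(-c3cn(-c4ccccc4)nc3-c3ccc(Cl)cc3)nc2c1`, has not yet been measured. It differs from compound 3 by fluoro in place of hydrogen on an aromatic carbon. This is the same kind of change as from compound 1 to compound 2, but not the same: in compound 2 the fluoro enters para to a large group, whereas in compound 4 it enters on a ring that is part of a fused or bridged system of two rings, meta to a fused ring and para to a fused ring. How the core of compound 3 differs from that of compound 1 is not broken down here.

For compound 4 the step that the limit leaves unreadable from compound 3 to compound 4 is expected to be small, because a step that the two limits leave unreadable from compound 1 to compound 2 could not be read and all three measured values sit at the limit. Compound 4 is estimated at 60000 nM, between 30000 nM and 200000 nM.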

Compound 4, half-maximal inhibitory concentration: > 50000 nM
Compound 4: only a limit was reported (the forecaster's own chance of this, stated with the estimate: 85%); the middle value is on the limit's open side.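

In this assay compound 4 gives > 50000 nM, which is a limit of the assay and not a number. The step between compound 3 and compound 4 cannot be read, because every compound shown sits at the same limit: the limit of > 50000 nM in this assay, at which 4 of the 4 values shown sit. The compounds shown leave open how strongly any of them acts on these cells, and whether fluoro in place of hydrogen changes that at all.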